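Methyl for chloro on the pyridine-like core of compound 2

The compounds below may be only part of what the source reports. "The series", "measured", "known", "first", "only" and "open" are said of these compounds alone.

Among the measured compounds shown here, compound 2, `Clc1cc(N2C[C@@H]3CCNC[C@@H]32)cnc1Cl`, gives the highest of the two numbers measured so far in a functional assay on HEK293 cells for agonist activity at Neuronal acetylcholine receptor; alpha4/beta2 (Homo sapiens), read by FLIPR; a lower number here means that less compound is needed, a higher number that more compound is needed for the effect: compound 2 gives 271 nM. For the measured compounds named here, the nearest neighbour is compound 1, `Clc1ccc(N2C[C@@H]3CCNC[C@@H]32)cn1`, which in this assay gives 37.4 nM; the step of a 7.2-fold higher number from compound 1 to compound 2 (0.86 log units; beyond the scatter) is the single measured step that bears on the question, and it is the only one available.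

Compound 3, `Cc1cc(N2C[C@@H]3CCNC[C@@H]32)cnc1Cl`, is not yet measured. Its change from compound 2 is methyl in place of chloro on an aromatic carbon. The measured step shows that putting chloro in place of hydrogen at this carbon raised the number of compound 2 beyond the scatter; a methyl at the same carbon is neither hydrogen nor chloro, so the expected outcome for compound 3 is a number somewhat below that of compound 2 but not as low as that of compound 1. Compound 3 is therefore estimated at 130 nM, within a range of 45 nM to 380 nM, meaning an expected step of a 2.1-fold lower number from compound 2 to compound 3 (0.32 log units; beyond the scatter).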

Compound 3, half-maximal effective concentration: 76.1 nM
Compound 3: middle estimate off by 1.7-fold (0.23 log units), on the high side; measured number inside the range.
By their numbers in this assay, from the lowest: compound 1; then compound 3; then compound 2.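

In this assay, this carbon, ortho to a chloro group and two atoms from the ring nitrogen, responds to which group it carries and not only to whether it carries one: a 3.6-fold lower number from compound 2 to compound 3 (0.55 log units; beyond the scatter) separates two groups of one heavy atom each. Methyl is not equivalent to hydrogen either, with a 2.0-fold higher number from compound 1 to compound 3 (0.31 log units; beyond the scatter) in this series, so from the lowest number the order at this carbon runs hydrogen, methyl, chloro. No measurement given here accounts for that order.

The compounds shown leave open how an amine, a methoxy group or a nitrile at this carbon would compare with these three. They also leave open whether the same order would hold if the chloro group that all three compounds share were replaced.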